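This account rests on a few compounds, and the source may have more. Where it says the series, first, only, none or still open, it means among the compounds named here.

Measured compounds:

compound 1, `O=C(Nc1ccccc1)Nc1cccc(CNc2nccnc2Cl)c1`, 15600 nM in a functional assay on HepG2 cells (Homo sapiens) for antiproliferative activity, read by MTT assay, with a stated time of 48 h; on this read-out lower numbers stand for stronger inhibition and higher numbers for weaker inhibition
compound 2, `O=C(Nc1ccc(Cl)cc1)Nc1cccc(CNc2nccnc2Cl)c1`, 8350 nM in this assay
compound 3, `Cc1ccc(NC(=O)Nc2cccc(CNc3nccnc3Cl)c2)cc1`, 11500 nM in this assay

The three measured compounds share one core and differ only in the group attached to the outer ring. From compound 1 to compound 2 the difference is chloro in place of hydrogen on an aromatic carbon, and in this assay this gave a 1.9-fold lower number from compound 1 to compound 2 (0.27 log units; within the scatter). From compound 1 to compound 3 the difference is methyl in place of hydrogen on an aromatic carbon, with a 1.4-fold lower number from compound 1 to compound 3 (0.13 log units; within the scatter). Between compound 2 and compound 3 the numbers sit close together, a 1.4-fold higher number from compound 2 to compound 3 (0.14 log units; within the scatter).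

Compound 4, `Cc1ccc(NC(=O)Nc2cccc(CNc3nccnc3Cl)c2)cc1Cl`, has not yet been measured. It differs from compound 3 by chloro in place of hydrogen on an aromatic carbon. This is the same kind of change as that from compound 1 to compound 2, but not the same: in compound 2 the chloro sits para to a large group, while in compound 4 it sits ortho to a methyl group and meta to a large group. The cores of the two pairs differ by methyl in place of hydrogen on an aromatic carbon.

For compound 4 in this assay the expectation rests on compound 1 and compound 2 because a 1.9-fold lower number from compound 1 to compound 2 (0.27 log units; within the scatter) shows what the chloro did there, and on compound 3 because 11500 nM is the starting point. The expected step is a 1.6-fold lower number from compound 3 to compound 4 (0.22 log units; within the scatter), about the size of the earlier one and likewise within the scatter. Compound 4 is therefore estimated at 7000 nM, between 3000 nM and 16000 nM.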

Compound 4, half-maximal inhibitory concentration: 11300 nM
Compound 4: middle estimate off by 1.6-fold (0.21 log units), on the low side; the range from low to high includes it.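

In this assay, chloro in place of hydrogen on the outer ring of compound 3 gave a 1.0-fold lower number from compound 3 to compound 4 (0.01 log units; within the scatter), and set beside the earlier case, the two steps cannot be told apart: the same change on two cores in this assay, a 1.9-fold lower number (0.27 log units; within the scatter) from compound 1 to compound 2 and a 1.0-fold lower number (0.01 log units; within the scatter) from compound 3 to compound 4, 1.8-fold (0.26 log units) apart, within the scatter of two such steps The wider comparisons also stay inside the scatter, with a 1.4-fold higher number from compound 2 to compound 4 (0.13 log units; within the scatter) and a 1.4-fold lower number from compound 1 to compound 4 (0.14 log units; within the scatter), so the four compounds shown cannot be separated from one another on this read-out. This is consistent with the change carrying over from one core to the other, but it does not show that it carries over with a real and constant size, as neither step stands clear of the scatter, and the chloro also does not occupy the same place in the two pairs, so the comparison is not a strict test of transfer.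

The compounds shown leave open whether a group of a different kind on the outer ring, such as an amine, a carboxylic acid or a trifluoromethyl, would move the number beyond the scatter. They also leave open how 3-chlorophenyl in place of phenyl would read without the methyl group, which would set the chloro at the place it holds in compound 4 on the core of compound 1.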